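Swapping an Oxime for a Methylsulfinyl Group

The source may hold more compounds than are shown below. What is called first, only, known or untested is meant among the compounds shown, and "the series" means these compounds.

Of the compounds shown here, three have been measured in an ADME assay on L1210/0 cells (Mus musculus) for cytotoxicity, with a stated time of 48 h; a lower number here means a stronger inhibitor, a higher number a weaker inhibitor. Compound 1 `OC[C@@H]1C[C@H](Cn2cnc3c(NC4CCC4)ncnc32)c2c(-c3ccccc3)nnc(-c3ccccc3)c21` gives 90800 nM, compound 2 `COc1ccc(C(=O)/C=C/c2cc(=O)[nH]c(=O)n2COCCO)cc1` gives 33500 nM, and compound 3 `O=c1[nH]c(=O)n([C@H]2C[C@H](O)[C@@H](CO)O2)cc1/C=N/O` gives 15500 nM. On these numbers compound 3 stands lowest of the three: compound 2 is nearest with a higher number, beyond the scatter, and compound 1 is furthest with a still higher number, also beyond the scatter. All three are weak inhibitors in this assay.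

Compound 4 `C[S+]([O-])c1cn([C@H]2C[C@H](O)[C@@H](CO)O2)c(=O)[nH]c1=O` has not yet been measured. It differs from compound 3 in one place: a group of 3 heavy atoms (1 carbon, 1 oxygen, 1 sulfur; no ring) in place of a group of 3 heavy atoms (1 carbon, 1 nitrogen, 1 oxygen; no ring), on an aromatic carbon. The change sits on an aromatic carbon of a six-membered aromatic ring with two nitrogens, two atoms from the ring nitrogen, and the entering group carries no hydrogen-bond donor where the leaving group carried one.

For the measured compounds named here, no step between measured compounds resembles this change, so nothing measured guides the direction. The expectation for compound 4 in this assay is a step of a 2.3-fold higher number from compound 3 to compound 4 (0.35 log units; beyond the scatter), toward a somewhat weaker inhibitor, though a result within the scatter would not surprise. Compound 4 is estimated at 35000 nM, with a range from 9000 nM to 150000 nM.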

Compound 4, half-maximal inhibitory concentration: > 200000 nM
Compound 4 gave a limit, no number; the forecaster's own chance of this, stated with the estimate: 25%; at least 5.7-fold (0.75 log units) between middle value and limit.
By their numbers in this assay, from the lowest: compound 3; then compound 2; then compound 1. At a limit, above all of these: compound 4.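

Compounds 1, 2 and 3 differ from one another in more than one place, so they could not show what any single group contributes. Compounds 3 and 4 share their core and differ only on this aromatic carbon, two atoms from the ring nitrogen, and in this assay replacing the oxime with the methylsulfinyl group gives an at least 12-fold higher number from compound 3 to compound 4 (1.11 log units; beyond the scatter), a large step toward a weaker inhibitor even though both groups have 3 heavy atoms. Compound 4 gives a limit and not a number, so the step marks only the smallest change the data allow: the limit of > 200000 nM in this assay, at which 1 of the 4 values shown sits.

The entering group carries no hydrogen-bond donor where the oxime carried one, but a single step cannot tell whether that difference, or some other difference between the two groups, matters here. On these data alone, it also remains open how a simple methyl group, an amine or a carboxylic acid on this carbon would compare with the oxime in this assay.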